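The source may hold more compounds than are shown below. What is called first, only, known or untested is meant among the compounds shown, and "the series" means these compounds.

Compound 1 `O=C(O)c1cccc(COc2ccc(OCCOCCNC3CCCC3)cc2)c1`: > 100000 nM
Compound 2 `c1ccc(COc2ccc(OCCOCCNc3ccncc3)cc2)cc1`: 20600 nM
Compound 3 `Clc1ccc(COc2ccc(OCCOCCNC3CCCC3)cc2)cc1`: not yet measured

In a functional assay on SK-OV-3 cells (Homo sapiens) for inhibition, read by CCK-8 assay, with a stated time of 70 h (a lower number here means a stronger inhibitor, a higher number a weaker inhibitor), compound 1 gives > 100000 nM, which is a limit of the assay and not a number. Compound 1 therefore stands at the limit of > 100000 nM in this assay, at which 1 of the 2 values shown sits. Compound 3 keeps the core of compound 1 and carries 4-chlorophenyl in place of 3-carboxyphenyl on a saturated chain carbon bound to an oxygen on an aromatic ring. For the measured compounds named here, no measured step shows the size of this change. A step toward stronger inhibition in this assay, beyond the scatter, is nevertheless expected. Going by the values given here, the only number available as an anchor comes from compound 2, which gives 20600 nM. The expected change is an at least 8.3-fold lower number from compound 1 to compound 3 (0.92 log units; beyond the scatter). For compound 3 the estimated value is 12000 nM, with an expected range of 3000 nM to 45000 nM.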

Compound 3, half-maximal inhibitory concentration: 7670 nM
Estimate against measurement, compound 3: 1.6-fold (0.19 log units) above; the measured number falls inside the stated range.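

In this assay, 4-chlorophenyl in place of 3-carboxyphenyl on a saturated chain carbon bound to an oxygen on an aromatic ring gives an at least 13-fold lower number from compound 1 to compound 3 (1.11 log units; beyond the scatter), which shows that the group held at this place can shift the read-out well beyond the scatter. For the compounds shown here, compound 1 stands at a limit of the assay and not at a number, so the true size of the step stays unknown and only its lower bound is given: the limit of > 100000 nM in this assay, at which 1 of the 3 values shown sits. Compound 1 and compound 2 differ in more than one place and offered no step, so this is the only change at this position that can be read.

The step changes the group and its ring position together, so the compounds shown do not separate the loss of the carboxylic acid from the arrival of the chlorine. A 3-chlorophenyl or a 4-carboxyphenyl on the same core would tell these apart.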